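The source may hold more compounds than are shown below. What is called first, only, known or untested is meant among the compounds shown, and "the series" means these compounds.

Measured so far:
Compound 1, `O=C(/C(=C\c1ccc(Cl)cc1Cl)S(=O)(=O)c1ccc(Br)cc1)c1ccc(Cl)cc1`: 50000 nM
Compound 2, `Cc1cc(C)cc(/C=C(\C(=O)c2ccc(Cl)cc2)S(=O)(=O)c2ccc(Br)cc2)c1`: 10000 nM
Compound 3, `Cc1ccc(S/C(=C/c2ccc(Cl)cc2Cl)C(=O)c2ccc(Cl)cc2)cc1`: 10000 nM

All three were tested in a functional assay on DU-145 cells (Homo sapiens) for inhibition, read by trypan blue exclusion, with a stated time of 96 h; on this read-out higher numbers stand for weaker inhibition of growth and lower numbers for stronger inhibition of growth. Compound 1 gives the highest of the three numbers. Compound 2 is built on the same core as compound 1 and differs from it in one place: 3,5-dimethylphenyl in place of 2,4-dichlorophenyl on a double-bonded chain carbon bound to a double-bonded chain carbon. This change made a step of a 5.0-fold lower number from compound 1 to compound 2 (0.70 log units; beyond the scatter), so compound 2 inhibits growth more strongly than compound 1.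

Compound 3 has a different core from compound 1; how the two cores differ is not broken down here. In this assay compound 3 sits level with compound 2 at the digits printed, and the two together give the lowest numbers of the set, while compound 1 lies farther off.

Compound 4, `Cc1ccc(S/C(=C/c2cc(C)cc(C)c2)C(=O)c2ccc(Cl)cc2)cc1`, has not yet been measured. It is related to compound 3 in exactly the way compound 2 is related to compound 1: 3,5-dimethylphenyl in place of 2,4-dichlorophenyl on a double-bonded chain carbon bound to a double-bonded chain carbon. Because the change from compound 1 to compound 2 gave a 5.0-fold lower number from compound 1 to compound 2 (0.70 log units; beyond the scatter), the same change on the core of compound 3 is expected to lower the number by a similar amount, though whether the second core carries it the same way is not known from these compounds alone. The expected step is a 3.3-fold lower number from compound 3 to compound 4 (0.52 log units; beyond the scatter). Compound 4 is therefore estimated to give about 3000 nM in this assay, most likely between 800 nM and 12000 nM.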

Compound 4, concentration for 50% growth inhibition: 50000 nM
Compound 4: middle estimate off by 17-fold (1.22 log units), on the low side; the measured number lies above the stated range.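

In this assay, putting 3,5-dimethylphenyl in place of 2,4-dichlorophenyl on the second core gave a 5.0-fold higher number from compound 3 to compound 4 (0.70 log units; beyond the scatter), which means weaker rather than stronger inhibition of growth. Set beside the earlier use of this change, the result runs in the opposite direction, so in this series the effect of the change did not carry from one core to the other: the same change on two cores in this assay, a 5.0-fold lower number (0.70 log units; beyond the scatter) from compound 1 to compound 2 and a 5.0-fold higher number (0.70 log units; beyond the scatter) from compound 3 to compound 4, 25-fold (1.40 log units) apart, beyond the scatter of two such steps This shows that a gain seen on one core cannot safely be assumed on another, but with only one matched pair on each core, it does not show why the two cores respond differently or what the same change would do on a third core.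

The compounds shown leave open whether the reversal is special to these two groups or also appears with others at this place on the double-bonded chain carbon, such as a phenyl ring carrying an amine or a carboxylic acid, or a longer chain in place of the ring. They also leave open which part of the difference between the two cores decides the direction of the change.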